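Changing the 2-methoxyphenyl group of compound 3

A few compounds are considered here, and "the series" means these few. Any claim that something is new, unique, unknown or untested is made for them only; others in the source may bear on it.

Compound 1 `COc1ccccc1OS(=O)(=O)c1ccc(N2CCN(C)C2=O)cc1`: 26000 nM
Compound 2 `Cc1ccc(OS(=O)(=O)c2ccc(N3CCN(C)C3=O)cc2)cc1`: > 100000 nM (a limit)
Compound 3 `CCN1CCN(c2ccc(S(=O)(=O)Oc3ccccc3OC)cc2)C1=O`: > 100000 nM (a limit)

These results come from a functional assay on HT-29 cells (Homo sapiens) for antiproliferative activity, read by sulforhodamine B assay, with a stated time of 48 h; on this read-out higher numbers stand for weaker inhibition and lower numbers for stronger inhibition. Compound 3 has no exact number and stands at the limit of > 100000 nM in this assay, at which 2 of the 3 values shown sit. Compound 4 `CCN1CCN(c2ccc(S(=O)(=O)Oc3cccc(Cl)c3)cc2)C1=O` differs from compound 3 in one place: 3-chlorophenyl in place of 2-methoxyphenyl on an oxygen. The closest measured change is an at least 3.8-fold higher number from compound 1 to compound 2 (0.58 log units; beyond the scatter), a swap on the same oxygen that also removed 2-methoxyphenyl. The other measured change, an at least 3.8-fold higher number from compound 1 to compound 3 (0.58 log units; beyond the scatter), lies elsewhere in the molecule and leaves this oxygen untouched. Neither change points to a recovery of activity, so no step beyond the scatter is expected. The expected change is an at least 1.1-fold lower number from compound 3 to compound 4 (0.04 log units; that floor lies within the scatter). For compound 4 the estimated value is 90000 nM, with an expected range of 20000 nM to 200000 nM.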

Compound 4, half-maximal inhibitory concentration: 6800 nM
Compound 4: the middle estimate sits 13-fold (1.12 log units) above what was measured, outside the stated range (below it).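

Putting 3-chlorophenyl in place of 2-methoxyphenyl on this oxygen gives an at least 14-fold lower number from compound 3 to compound 4 (1.16 log units; beyond the scatter) in this assay, so a swap here can bring activity back, whereas the earlier swap on the same oxygen gave an at least 3.8-fold higher number from compound 1 to compound 2 (0.58 log units; beyond the scatter). Compound 4 also shows that 2-methoxyphenyl is not required for measurable activity with this core. The full size of the step stays unknown, since compound 3 has only a limit: the limit of > 100000 nM in this assay, at which 2 of the 4 values shown sit.

Going by these compounds, whether 3-chlorophenyl would also help on the core of compound 1 remains open. So does how 3-methoxyphenyl or 4-chlorophenyl would compare on this oxygen.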